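The compounds below may be only part of what the source reports. "The series", "measured", "known", "first", "only" and "open" are said of these compounds alone.

Working notes on the sulfonamide series.

For the measured compounds named here, compound 1 `O=C(NCc1ccc(CNS(=O)(=O)c2ccc(Cl)cc2)cc1)c1ccc(CNc2ncccn2)cc1` holds the lowest number of the three compounds measured so far. In an assay on MDA-MB-231 cells for binding affinity to C-X-C chemokine receptor type 4 (Homo sapiens), read by microscopy, with stated times of 10 min and 30 min (a lower number here means that less compound is needed, a higher number that more compound is needed for the effect), compound 1 gives 100 nM. Compound 2 `O=C(NCc1ccc(CNS(=O)(=O)c2cccc3ccccc23)cc1)c1ccc(CNc2ncccn2)cc1` gives 1000 nM in this assay, and compound 3 `O=C(NCc1ccc(CNS(=O)(=O)c2cccc(F)c2)cc1)c1ccc(CNc2ncccn2)cc1` gives 1000 nM. Both measured changes at the sulfonyl sulfur moved the number the same way: a 10-fold higher number from compound 1 to compound 2 (1.00 log units; beyond the scatter) and a 10-fold higher number from compound 1 to compound 3 (1.00 log units; beyond the scatter), while no change at the digits printed from compound 2 to compound 3 (within the scatter) shows the two replacements of 4-chlorophenyl ending at the same point.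

Compound 4 `Cc1ccccc1S(=O)(=O)NCc1ccc(CNC(=O)c2ccc(CNc3ncccn3)cc2)cc1` has not yet been measured. Its difference from compound 1: 2-methylphenyl in place of 4-chlorophenyl on a sulfonyl sulfur. Going by the values given here, nothing measured here tells how 2-methylphenyl behaves on a sulfonyl sulfur; the only guide is that every departure from 4-chlorophenyl recorded so far, whether to naphthalen-1-yl or to 3-fluorophenyl, gave a step beyond the scatter toward a higher number. On that basis a higher number than compound 1 is expected for compound 4, though with two examples only the size is uncertain and a result within the scatter of compound 1 cannot be excluded. The expected step is a 5.0-fold higher number from compound 1 to compound 4 (0.70 log units; beyond the scatter). For compound 4 in this assay the estimate is 500 nM, with a range from 150 nM to 2000 nM.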

Compound 4, effective concentration (reported as EC, without a stated level of effect): 10 nM
The estimate for compound 4 lay 50-fold (1.70 log units) above the measured number; measured number below the stated range.
By their numbers in this assay, from the lowest: compound 4; then compound 1; then compounds 2 and 3 (each within the scatter of the next).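

Read in this assay, the substituent on the sulfonyl sulfur can move the number down as well as up: 2-methylphenyl in place of 4-chlorophenyl gives a step in the opposite direction to the earlier replacements (a 10-fold lower number from compound 1 to compound 4 (1.00 log units; beyond the scatter)), so 4-chlorophenyl does not hold the lowest number at this position. For the compounds shown here, the span at this single position is also wider than the earlier compounds showed, with large steps to 2-methylphenyl from 3-fluorophenyl (a 100-fold lower number from compound 3 to compound 4 (2.00 log units; beyond the scatter)) and from naphthalen-1-yl (a 100-fold lower number from compound 2 to compound 4 (2.00 log units; beyond the scatter)). The leaving and entering groups match in heavy-atom count, in ring type and in hydrogen-bond donors and acceptors, so these counts do not separate compound 1 from compound 4, and no supporting evidence accounts for the difference.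

Still open, as far as these compounds go, is whether the lower number follows the methyl group or its place on the ring, a question that 4-methylphenyl and 2-chlorophenyl on the sulfonyl sulfur would address. Also open, from the compounds shown here alone, is how this position responds to a group without an aromatic ring, such as cyclohexyl, or to a 2-methoxyphenyl group.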